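Swapping Ethyl for Thiophenyl on a Shared Core

A few compounds are considered here, and "the series" means these few. Any claim that something is new, unique, unknown or untested is made for them only; others in the source may bear on it.

Of the compounds shown here, three built on one shared core have been tested in a functional assay on NPC-TW01 cells (Homo sapiens) for inhibition, read by MTT assay, with a stated time of 72 h; a higher number here means a weaker inhibitor of growth, a lower number a stronger inhibitor of growth. Compound 1 `COC(=O)c1nc(C)n(-c2ccccc2C(F)(F)F)n1` gives > 100000 nM in this assay, which is a limit of the measurement rather than a number. Compound 2 `COC(=O)c1nc(C)n(-c2ccc(Cl)cc2)n1` gives 17500 nM in this assay. Among the measured compounds shown here, compound 3 `CCc1nc(C(=O)OC)nn1-c1ccc(F)cc1` gives 15800 nM in this assay, the lower of the two numbers known; its gap to compound 2 lies within the usual scatter of repeated measurements, so the two cannot be told apart on these results.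

Compound 4 `COC(=O)c1nc(-c2ccsc2)n(-c2ccc(F)cc2)n1` differs from compound 3 in a single place: thiophen-3-yl in place of ethyl on an aromatic carbon. No pair of measured compounds differs in this way, so neither the size nor the direction of such a step is shown by the data. A small chain is exchanged for a larger aromatic ring, and the expectation is a modest move toward a lower number, of a size that may not exceed the scatter. Compound 4 is therefore estimated to give 9000 nM, with a likely range from 2500 nM to 40000 nM. That estimate corresponds to an expected step of a 1.8-fold lower number from compound 3 to compound 4 (0.24 log units; within the scatter).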

Compound 4, concentration for 50% growth inhibition: 10700 nM
The estimate for compound 4 lay 1.2-fold (0.08 log units) below the measured number, within the range that was stated.
By their numbers in this assay, from the lowest: compounds 4, 3 and 2 (each within the scatter of the next). At a limit, above all of these: compound 1.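

Among the compounds shown here, at this place, an aromatic carbon between two ring nitrogen atoms, the earlier compounds carried only a small chain, so they gave no sign of how a ring would fare there. In this assay, exchanging ethyl for thiophen-3-yl gives a 1.5-fold lower number from compound 3 to compound 4 (0.17 log units; within the scatter), which means that a group with more heavy atoms, an aromatic ring of its own and a sulfur atom can sit at this place without a change that can be told apart from repeated-measurement noise. This single pair shows that a larger aromatic ring is accepted here in this assay, but it does not show a real gain, and it says so only for the shared core with the fluorine-bearing phenyl ring of compound 3 and compound 4.

As far as these compounds go, whether a phenyl ring, an amine, a carboxylic acid or a longer chain at this place would move the number beyond the scatter remains open, since one step cannot define a trend in either direction. No measurement among those shown speaks to why this exchange leaves the number where it is.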